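This account rests on a few compounds, and the source may have more. Where it says the series, first, only, none or still open, it means among the compounds named here.

In an ADME assay on MDBK cells (Bos taurus) for cytotoxicity, read by MTT assay, with a stated time of 96 h (a lower number here means that less compound is tolerated, a higher number that more compound is tolerated), three compounds sharing one core have been measured by their half-maximal cytotoxic concentration. Compound 1 `C/C(=N\NC(N)=S)c1ccc2[nH]c(-c3ccc(C(F)(F)F)cc3)nc2c1` gives 5000 nM. Compound 2 `COc1ccc(-c2nc3cc(/C(C)=N/NC(N)=S)ccc3[nH]2)cc1` gives 13000 nM, the higher of the two actual numbers. Compound 3 `COc1ccc(-c2nc3cc(/C(C)=N/NC(N)=S)ccc3[nH]2)c(OC)c1` is reported only as a limit, > 100000 nM. Compound 2 thus stands above compound 1, while its position relative to the top of the series is marked by that limit.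

The next compound is compound 4 `C/C(=N\NC(N)=S)c1ccc2[nH]c(-c3ccoc3)nc2c1`, which has furan-3-yl in place of 4-methoxyphenyl on an aromatic carbon of a five-membered aromatic ring with 2 nitrogen (furan-3-yl in place of 4-methoxyphenyl on an aromatic carbon). Among the compounds with values here, two measured steps bear on this group, though both only exchange substituents on the six-membered ring that compound 4 gives up. The first is a 2.6-fold higher number from compound 1 to compound 2 (0.41 log units; beyond the scatter), and the second is an at least 7.6-fold higher number from compound 2 to compound 3 (0.88 log units; beyond the scatter). Both raised the number, but neither replaces the whole ring, so they are only a loose guide. A modest upward move is therefore expected, a 1.7-fold higher number from compound 2 to compound 4 (0.23 log units; within the scatter). For compound 4 the estimated value is 22000 nM, with an expected range of 7000 nM to 70000 nM.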

Compound 4, half-maximal cytotoxic concentration: > 100000 nM
Compound 4 was reported as a limit (the forecaster's own chance of this, stated with the estimate: 10%); middle value at least 4.5-fold (0.65 log units) away from the limit.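

In this assay, exchanging the whole 4-methoxyphenyl group for furan-3-yl, on the aromatic carbon between two ring nitrogen atoms, gives an at least 7.6-fold higher number from compound 2 to compound 4 (0.88 log units; beyond the scatter). The earlier steps shown here only changed substituents on the six-membered aromatic ring, whereas this one shows that the ring itself can give way to a five-membered aromatic ring with 1 hetero atom and the number still rises beyond the scatter. The value of compound 4 is a limit, so the step has no upper end, and compound 3 sits at that same limit: the limit of > 100000 nM in this assay, at which 2 of the 4 values shown sit.

As far as these compounds go, what a thiophen-3-yl or a pyridin-3-yl group would give at this position stays open, so the part played by the furan oxygen cannot be separated from that of ring size. From the compounds shown here alone, how far compound 4 lies past its limit also remains unknown.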